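The compounds below may be only part of what the source reports. "The series", "measured", "known", "first", "only" and "open" are said of these compounds alone.

Of the compounds shown here, two share one core and have been measured in an ADME assay on HepG2 cells (Homo sapiens) for inhibition, with a stated time of 48 h; on this read-out higher numbers stand for an effect only at larger amounts of compound and lower numbers for an effect already at smaller amounts. Compound 1, with structure `C[C@@H](C(=O)N1CC2CC2C1)N1CCN(S(=O)(=O)c2ccc(C(C)(C)C)cc2)CC1`, reaches only the assay limit and is recorded in this assay as > 40000 nM. Compound 2, with structure `CC1CCN(C(=O)C(C)N2CCN(S(=O)(=O)c3ccc(C(C)(C)C)cc3)CC2)CC1`, likewise gives in this assay only the limit of > 40000 nM. Compound 2 therefore stands where all the numbers shown stand: at the limit of > 40000 nM in this assay, at which 2 of the 2 values shown sit, so that no value separates it from compound 1, and no step between measured compounds is available.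

Compound 3, with structure `CC(C(=O)N(C)Cc1ccccc1)N1CCN(S(=O)(=O)c2ccc(C(C)(C)C)cc2)CC1`, has not yet been measured. It differs from compound 2 in a single place: benzyl(methyl)amino in place of 4-methylpiperidin-1-yl on a carbonyl carbon. Since compound 2 sits at the limit, there is no measured number from which a step could move. The expectation is that compound 3 stays in the same region, with an expected step from compound 2 to compound 3 of a step that the limit leaves unreadable from compound 2 to compound 3, and that compound 3 in this assay is estimated at 60000 nM, within a range from 20000 nM to 200000 nM, most likely again as a limit rather than a number.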

Compound 3, half-maximal effective concentration: > 40000 nM
Compound 3: a limit, no number; the forecaster's own chance of this, stated with the estimate: 80%; the middle value is on the limit's open side.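

In this assay compound 3 gives > 40000 nM, which is a limit and not a number. Among the compounds shown here, compound 2 sits at the same limit, so no step from compound 2 to compound 3 can be read, and all the compounds share that limit: the limit of > 40000 nM in this assay, at which 3 of the 3 values shown sit. The compounds shown leave open whether benzyl(methyl)amino in place of 4-methylpiperidin-1-yl on a carbonyl carbon changes the read-out at all.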